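From furan-2-yl to 4-chlorophenyl in a level series

This account rests on a few compounds, and the source may have more. Where it says the series, first, only, none or still open, it means among the compounds named here.

Of the compounds shown here, three built on one shared core have so far been measured in a functional assay on DU-145 cells (Homo sapiens) for cytotoxicity, read by ELISA, with a stated time of 4 days (on this read-out higher numbers stand for weaker inhibition and lower numbers for stronger inhibition), and their numbers lie close together. Compound 1 `Cc1ccsc1-c1cc(-c2ccco2)cc(-c2ccccc2Cl)n1` gives 29900 nM there, compound 2 `Cc1ccsc1-c1cc(-c2ccco2)cc(-c2ccc(Cl)cc2)n1` gives 26700 nM and compound 3 `Cc1ccsc1-c1cc(-c2ccoc2)cc(-c2ccco2)n1` gives 30400 nM, so compound 3 stands level with the other two, all three values falling within the scatter of one another.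

Compound 4 `Cc1ccsc1-c1cc(-c2ccoc2)cc(-c2ccc(Cl)cc2)n1` departs from compound 3 by a single change, (4-chlorophenyl in place of furan-2-yl on an aromatic carbon), made on an aromatic carbon next to the ring nitrogen. Among the measured compounds shown here, no measured pair isolates this exchange. For the measured compounds named here, the one measured step, a 1.1-fold lower number from compound 1 to compound 2 (0.05 log units; within the scatter), swaps one chlorophenyl group for another rather than a furan for a chlorophenyl, so it bears only indirectly, and it stays within the scatter. Compound 2, which carries the same 4-chlorophenyl group but has furan-2-yl in place of furan-3-yl, gives 26700 nM and offers a second indirect guide. Nothing here points to a step beyond the scatter in this assay, and the expected step is a 1.1-fold lower number from compound 3 to compound 4 (0.04 log units; within the scatter) in size. For compound 4 the estimated value is 28000 nM, with an expected range of 14000 nM to 50000 nM in this measurement.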

Compound 4, half-maximal inhibitory concentration: 20100 nM
Estimate against measurement, compound 4: 1.4-fold (0.14 log units) above; low and high end bracket the measured number.
By their numbers in this assay, from the lowest: compounds 4, 2, 1 and 3 (each within the scatter of the next).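

In this assay, the position next to the ring nitrogen now has a direct reading: 4-chlorophenyl in place of furan-2-yl gives a 1.5-fold lower number from compound 3 to compound 4 (0.18 log units; within the scatter), so this read-out does not separate the six-membered carbon ring bearing chlorine from the five-membered aromatic ring with its oxygen. The second exchange that can now be read on its own, furan-3-yl in place of furan-2-yl, gives a 1.3-fold lower number from compound 2 to compound 4 (0.12 log units; within the scatter), so the attachment point of the furan is likewise not told apart here, and all four compounds remain level with one another. Nothing available offers an explanation for these readings.

On these data alone, all four compounds carry only furan or chlorophenyl groups at these places, so it stays open whether an amine, a carboxylic acid or a longer alkyl chain next to the ring nitrogen would shift the number beyond the scatter. Also open, as far as these compounds go, is what a change to the 3-methylthiophen-2-yl group, common to all four compounds, would do in this assay.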